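Swapping a furan for a pyridine on a ketone-bearing oxazole

The compounds below may be only part of what the source reports. "The series", "measured", "known", "first", "only" and "open" are said of these compounds alone.

Of the compounds shown here, three have so far been measured in an assay on isolated protein for inhibition of Fatty-acid amide hydrolase 1 (Homo sapiens); a higher number here means a weaker inhibitor, a lower number a stronger inhibitor. Compound 1, `CCCCCCCC/C=C\CCCCCCC(=O)c1ncc(-c2ccoc2)o1`, gives 610 nM, which is the higher of the two numbers that were actually read out. Its nearest neighbour is compound 3, `O=C(CCCCCCCCc1ccccc1)c1nc2ncccc2o1`, which gives 0.52 nM; that gap lies well beyond the usual scatter. For compound 2, `CCCCCCCC/C=C\CCCCCCC(=O)c1ccccn1`, this assay records only a limit, > 100000 nM, so no number is known for it; this is the limit of > 100000 nM in this assay, at which 1 of the 3 values shown sits.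

The step followed here leads from compound 1 to compound 4, `CCCCCCCC/C=C\CCCCCCC(=O)c1ncc(-c2ccncc2)o1`, and consists of pyridin-4-yl in place of furan-3-yl on an aromatic carbon. Within the data shown here, no pair of measured compounds differs in only this one place, so the size of the step cannot be read from the data. The two aromatic rings are of similar bulk and each carries a single hydrogen-bond acceptor, so a drastic change is not anticipated. The expectation is a modest improvement, with compound 4 estimated at 200 nM, within a range from 40 nM to 1000 nM. This corresponds to an expected step from compound 1 to compound 4 of a 3.1-fold lower number from compound 1 to compound 4 (0.48 log units; beyond the scatter), a shift that may not stand out from the scatter, although the value itself remains to be seen.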

Compound 4, inhibition constant: 56 nM
Compound 4: the middle estimate sits 3.6-fold (0.55 log units) above what was measured, and the stated range covers the measured number.
By their numbers in this assay, from the lowest: compound 3; then compound 4; then compound 1. At a limit, above all of these: compound 2.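

In this assay, pyridin-4-yl in place of furan-3-yl on the aromatic carbon next to the ring oxygen gives an 11-fold lower number from compound 1 to compound 4 (1.04 log units; beyond the scatter), the first step measured at this position. It shows that the group on this carbon is not a passive passenger: with the long chain, the ketone and the rest of the core unchanged, replacing one aromatic ring with another clearly shifts the inhibition constant. The two groups have the same count of hydrogen-bond acceptors and differ in ring size and in their hetero atom, but nothing measured here shows why the change has this size.

Among these compounds, with only two groups compared at this position, the effect of the larger ring cannot be separated from that of exchanging the oxygen for a ring nitrogen. A plain phenyl ring, which has no hetero atom, and pyridin-3-yl, which has its ring nitrogen in a different place, would help to separate these two effects, while an amine or a carboxylic acid on this carbon would show how far the position tolerates something other than an aromatic ring.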